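A pyridin-2-yl in place of a 4-methoxyphenyl

The compounds below may be only part of what the source reports. "The series", "measured", "known", "first", "only" and "open" are said of these compounds alone.

Compound 1 `COc1ccc(-c2cn(C[C@H]3c4c(ccc(O)c4C)[C@@H]4CC[C@@]5(C)C[C@]43CC5=O)nn2)cc1` was tested in a functional assay on A549 cells (Homo sapiens) for cytotoxicity, read by MTT assay, with a stated time of 4 days; a lower number here means a stronger inhibitor, a higher number a weaker inhibitor. In this assay compound 1 gives > 20000 nM, which is a limit of the assay and not a number. Two companions share the same core. Compound 2 `C=C1C[C@]23C[C@@]1(O)CC[C@H]2c1cc(Br)c(O)c(C)c1[C@@H]3Cn1cc(-c2ccc(C)cc2)nn1` gives > 20000 nM in this assay, again a limit. Compound 3 `C=C1C[C@]23C[C@@]1(O)CC[C@H]2c1ccc(O)c(C)c1[C@@H]3Cn1cc(-c2ccc(OC)cc2)nn1` gives > 20000 nM, likewise a limit. So compound 1 stands where all its companions stand, at the limit of > 20000 nM in this assay, at which 3 of the 3 values shown sit, and no measured step exists to show how a change on this core moves the read-out. Compound 4 `Cc1c(O)ccc2c1[C@H](Cn1cc(-c3ccccn3)nn1)[C@@]13CC(=O)[C@@](C)(CC[C@@H]21)C3` carries pyridin-2-yl in place of 4-methoxyphenyl on an aromatic carbon. With nothing measured on either side of this change, compound 4 is expected to stay near that same limit, so the step that the limit leaves unreadable from compound 1 to compound 4 is expected to be none beyond the scatter. Compound 4 is estimated at 25000 nM, within 8000 nM to 80000 nM.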

Compound 4, half-maximal inhibitory concentration: > 20000 nM
Compound 4 gave a limit, no number; the forecaster's own chance of this, stated with the estimate: 70%; the middle value is on the limit's open side.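

The step from compound 1 to compound 4 cannot be read, since both stop at a limit of the assay and give no number: the limit of > 20000 nM in this assay, at which 4 of the 4 values shown sit.

Going by these compounds, whether pyridin-2-yl in place of 4-methoxyphenyl changes the read-out at all stays open, as does which change on the shared core, if any, would give a measurable value.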